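Ester chain extension from compound 3 to compound 4

The source may report more compounds than this note shows. Statements on the series, on what has been measured and on what is new or still open speak of the compounds shown alone.

Compound 3 `CCCCCCCCCCCCOC(=O)CCC(=O)N1CCN(CCCOc2cc3c(Nc4ccc(F)c(Cl)c4)ncnc3cc2OC)CC1` stands second highest of the three numbers in a functional assay on A549 cells (Homo sapiens) for cytotoxicity, read by MTT assay, with a stated time of 24 h, tested at 10 uM (a higher number here means a weaker effect of the compound at the concentration tested, a lower number a stronger effect), where compound 3 gives 95.5%. Its nearest neighbour is compound 2 `CCCCCCCCCCOC(=O)CCC(=O)N1CCN(CCCOc2cc3c(Nc4ccc(F)c(Cl)c4)ncnc3cc2OC)CC1`, which gives 95.7% in this assay. The furthest is compound 1 `CCCCCCCCOC(=O)CCC(=O)N1CCN(CCCOc2cc3c(Nc4ccc(F)c(Cl)c4)ncnc3cc2OC)CC1`, which gives 87.3% in this assay. Compound 4 `CCCCCCCCCCCCCCCOC(=O)CCC(=O)N1CCN(CCCOc2cc3c(Nc4ccc(F)c(Cl)c4)ncnc3cc2OC)CC1` has not yet been measured. It differs from compound 3 by propyl in place of hydrogen on a saturated chain carbon, ten or more bonds along the chain from an oxygen next to a carbonyl group.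

The measured steps that bear on this change all run along the same saturated chain. The closest parallel is a number 0.2 percentage points lower from compound 2 to compound 3 (within the scatter). The two longer steps from the shortest chain read a number 8.4 percentage points higher from compound 1 to compound 2 (within the scatter) and a number 8.2 percentage points higher from compound 1 to compound 3 (within the scatter). None of these reaches beyond the scatter, so adding propyl in place of hydrogen at the same place is not expected to move this assay beyond the scatter either. The step of a number 1.5 percentage points lower from compound 3 to compound 4 (within the scatter) is therefore estimated to be small. Compound 4 is expected to give about 94% in this assay, with a range from 84% to 100%. The three measured compounds do not separate from one another, so no trend with chain length is claimed here.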

Compound 4, a percentage reported as activity, at one concentration (the size of the read-out at that concentration, not a potency): 92%
Estimate against measurement, compound 4: 2 percentage points above; the measured number falls inside the stated range.
By their numbers in this assay, from the lowest: compounds 1, 4, 3 and 2 (each within the scatter of the next).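

In this assay, the propyl in place of hydrogen, on a saturated chain carbon, gives a number 3.5 percentage points lower from compound 3 to compound 4 (within the scatter), and the pentyl change at that same place gives a number 3.7 percentage points lower from compound 2 to compound 4 (within the scatter). Within the data shown here, the heptyl change, on a saturated chain carbon eight bonds along the chain from an oxygen next to a carbonyl group, gives a number 4.7 percentage points higher from compound 1 to compound 4 (within the scatter), so the series now spans four chain lengths with no step leaving the scatter. With compound 4 at 92% in this assay, this added chain length still gives no trend in the read-out, and the ester chain shows no measurable dependence on length across these compounds.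

No measurement shown here bears on what underlies these numbers. Still open, on these data alone, is whether a longer chain, or an amine or a carboxylic acid at the end of the chain in place of the plain alkyl terminus, would give a step beyond the scatter in this assay.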